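Hydroxy in Place of Amino on a Sulfonamide Nitrogen

The source may report more compounds than this note shows. Statements on the series, on what has been measured and on what is new or still open speak of the compounds shown alone.

Three compounds have numbers so far:
Compound 1, `CS(=O)(=O)NNc1nonc1/C(=N/O)Nc1ccc(F)c(Br)c1`, in an assay on isolated protein for inhibition of Indoleamine 2,3-dioxygenase 1 (Homo sapiens), read by fluorescence, with a stated time of 60 min (a higher number here means a weaker inhibitor, a lower number a stronger inhibitor), gives 609 nM.
Compound 2, `CCNS(=O)(=O)CCNc1nonc1/C(=N/O)Nc1ccc(F)c(Br)c1`, in this assay gives 95 nM.
Compound 3, `NNS(=O)(=O)CCNc1nonc1/C(=N/O)Nc1ccc(F)c(Br)c1`, in this assay gives 135 nM.

Compound 3 holds the second highest of the three numbers. Two steps mark where it stands: a 1.4-fold higher number from compound 2 to compound 3 (0.15 log units; within the scatter), which lies within the scatter, and a 4.5-fold lower number from compound 1 to compound 3 (0.65 log units; beyond the scatter), which lies beyond it. The steps of a 6.4-fold lower number from compound 1 to compound 2 (0.81 log units; beyond the scatter) and a 4.5-fold lower number from compound 1 to compound 3 (0.65 log units; beyond the scatter) both replace the methanesulfonamido group with a two-carbon chain carrying a sulfonamide, and that chain is shared unchanged by compound 3 and compound 4.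

Compound 4, `O=S(=O)(CCNc1nonc1/C(=N/O)Nc1ccc(F)c(Br)c1)NO`, differs from compound 3 in one place: hydroxy in place of amino on a sulfonamide nitrogen. Within the data shown here, the only measured step at that same nitrogen is a 1.4-fold higher number from compound 2 to compound 3 (0.15 log units; within the scatter), and it stays within the scatter. Among the measured compounds shown here, an exchange of one small group for another on that nitrogen therefore has no precedent here for a shift beyond the scatter, and compound 4 is expected to sit close to compound 3, with a 1.1-fold higher number from compound 3 to compound 4 (0.05 log units; within the scatter). The estimate for compound 4 in this assay is 150 nM, within a range from 60 nM to 400 nM.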

Compound 4, half-maximal inhibitory concentration: 126 nM
Beside the measured number, compound 4's estimate is 1.2-fold (0.08 log units) above it; the range from low to high includes it.
By their numbers in this assay, from the lowest: compounds 2, 4 and 3 (each within the scatter of the next); then compound 1.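

In this assay the exchange of amino for hydroxy on this sulfonamide nitrogen leaves the number within the scatter (a 1.1-fold lower number from compound 3 to compound 4 (0.03 log units; within the scatter)), and the exchange of ethyl for hydroxy does the same (a 1.3-fold higher number from compound 2 to compound 4 (0.12 log units; within the scatter)). The earlier compounds shown here compared only amino with ethyl at this nitrogen, whereas three groups there now give numbers within the scatter of one another, so this small set shows no preference among them. The step away from methanesulfonamido also holds with the third group (a 4.8-fold lower number from compound 1 to compound 4 (0.68 log units; beyond the scatter)), which shows that the step seen with compound 2 and compound 3 does not depend on which of these three groups sits on the nitrogen. No evidence is available to account for this flat response.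

From the compounds shown here alone, whether a larger group on that nitrogen, such as a benzyl or a longer alkyl chain, or one carrying a carboxylic acid or a tertiary amine, would stay within the scatter remains open. Also open, going by these compounds, is how the number would respond to a plain unsubstituted sulfonamide, or to a propyl chain in place of the ethyl chain that carries the sulfonamide.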